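The source may hold more compounds than are shown below. What is called first, only, known or untested is meant among the compounds shown, and "the series" means these compounds.

Measured values in a functional assay on HEK293 cells for agonist activity at Glucose-dependent insulinotropic receptor (Homo sapiens), read by cAMP accumulation, with a stated time of 30 min; a lower number here means that less compound is needed, a higher number that more compound is needed for the effect:

compound 1 `CC1(COC(=O)N2CC3COCC(C2)C3Oc2ncnc(Nc3ccc(C#N)cc3Cl)c2F)COC1`: 188 nM
compound 2 `CC1(OC(=O)N2CC3COCC(C2)C3Oc2ncnc(Nc3ccc(C#N)cc3Cl)c2F)CCC1`: 10 nM
compound 3 `CC1(OC(=O)N2CC3COCC(C2)C3Oc2ncnc(Nc3cccnc3Cl)c2F)CC1`: 17 nM

Compound 3 stands second highest of the three numbers. Its nearest neighbour is compound 2, within the scatter; its furthest is compound 1, beyond the scatter. Going by the values given here, the only single-point step in the set is a 19-fold lower number from compound 1 to compound 2 (1.27 log units; beyond the scatter), which sits on the carbamate side of the shared core.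

Compound 4 `CC1(OC(=O)N2CC3COCC(C2)C3Oc2ncnc(Nc3ccc(F)cc3F)c2F)CC1` is the next member: 2,4-difluorophenyl in place of 2-chloropyridin-3-yl on a nitrogen on an aromatic ring. Among the compounds with values here, no measured step isolates a change at this nitrogen. Compounds 2 and 3 differ at this nitrogen and at the carbamate at the same time, and their values lie within the scatter of each other, so they give no direction for the aryl change alone. The step from compound 1 to compound 2 does not bear on it.

For compound 4 in this assay the expectation is therefore a number close to that of compound 3, with a step of a 1.8-fold higher number from compound 3 to compound 4 (0.25 log units; within the scatter) not beyond the scatter and a wide range. Compound 4 is estimated at 30 nM, between 8 nM and 120 nM.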

Compound 4, half-maximal effective concentration: 15 nM
Compound 4: middle estimate off by 2.0-fold (0.30 log units), on the high side; measured number inside the range.
By their numbers in this assay, from the lowest: compounds 2, 4 and 3 (each within the scatter of the next); then compound 1.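

In this assay, going by these compounds alone, 2,4-difluorophenyl in place of 2-chloropyridin-3-yl on a nitrogen on an aromatic ring gives a 1.1-fold lower number from compound 3 to compound 4 (0.05 log units; within the scatter), the only step in the set that isolates a change at this nitrogen. The ring of carbon only with two fluorines replaces the pyridine ring with its chlorine, and the step stays within the scatter, so this assay does not separate the two aryl groups when the carbamate is held constant. No measured evidence bears on this result.

Going by these compounds, whether the two aryl groups also remain within the scatter of each other on the 1-methylcyclobutyl carbamate of compound 2 stays open. Also open, on these data alone, is how this nitrogen tolerates a phenyl ring carrying an amine or a carboxylic acid, or a saturated cyclohexyl group.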